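This account rests on a few compounds, and the source may have more. Where it says the series, first, only, none or still open, it means among the compounds named here.

The measured compounds, each with its result in an assay on isolated protein for inhibition of aldehyde dehydrogenase 1A1 (Homo sapiens), read by spectrophotometry, tested at 10 uM; a higher number here means more inhibition at the concentration tested (going by the name of the read-out), a lower number less inhibition:
compound 1, `Cc1cccc(Cn2c(CN3CCN(C(=O)c4ccc([N+](=O)[O-])cc4)CC3)nc3ccccc32)c1`, gives 24.3%;
compound 2, `CC(=O)N1CCN(Cc2nc3ccccc3n2Cc2cccc(C)c2)CC1`, gives 70.3%;
compound 3, `Cc1cccc(Cn2c(CN3CCN(C(=O)c4ccc(C#N)cc4)CC3)nc3ccccc32)c1`, gives 20.8%.

Compound 3 stands at the low end of the three, but its gap to compound 1, a number 3.5 percentage points lower from compound 1 to compound 3 (within the scatter), is within the scatter, so these two cannot be told apart; only compound 2 stands clearly apart, by the step of a number 49.5 percentage points lower from compound 2 to compound 3 (beyond the scatter). Compound 4, `Cc1ccc(C(=O)N2CCN(Cc3nc4ccccc4n3Cc3cccc(C)c3)CC2)cc1`, is not yet measured. It differs from compound 3 in one place: methyl in place of cyano on an aromatic carbon. The two large steps, a number 46 percentage points higher from compound 1 to compound 2 (beyond the scatter) and a number 49.5 percentage points lower from compound 2 to compound 3 (beyond the scatter), both come from exchanging the methyl on a carbonyl carbon for a 4-nitrophenyl or 4-cyanophenyl, and compound 4 does not make that exchange. Going by the values given here, the only step that changes just the group on the aromatic ring, a number 3.5 percentage points lower from compound 1 to compound 3 (within the scatter), stayed within the scatter. The expected step in this assay is therefore a number 4.2 percentage points higher from compound 3 to compound 4 (within the scatter), not beyond the scatter. Compound 4 is estimated at 25%, with a likely range from 8% to 45%.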

Compound 4, a percentage reported as inhibition, at one concentration (the size of the read-out at that concentration, not a potency): 64.9%
For compound 4 the middle estimate is 39.9 percentage points below the measured one; measured number above the stated range.
By their numbers in this assay, from the lowest: compounds 3 and 1 (each within the scatter of the next); then compounds 4 and 2 (each within the scatter of the next).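

In this assay, the group on the aromatic ring, para to a large group, can decide the result: methyl in place of cyano gives a number 44.1 percentage points higher from compound 3 to compound 4 (beyond the scatter) and methyl in place of nitro gives a number 40.6 percentage points higher from compound 1 to compound 4 (beyond the scatter), although swapping nitro for cyano had changed little. The ring itself is thus not enough to bring the number down, since 4-methylphenyl in place of methyl on the carbonyl carbon gives a number 5.4 percentage points lower from compound 2 to compound 4 (within the scatter), so the earlier large drops go with the nitro and cyano groups carried on the ring. Nothing available explains this difference between the groups.

From the compounds shown here alone, it remains open where a methoxy group, a chlorine atom or an amine at this place would fall between these extremes. Going by these compounds, these numbers also come from a single concentration, so how potency differs remains open.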